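The source may report more compounds than this note shows. Statements on the series, on what has been measured and on what is new or still open speak of the compounds shown alone.

Measured compounds:
compound 1, `COc1c(C(=O)c2ccc3cc(C(=O)O)ccc3c2)ccc2c1C(C)(C)CCC2(C)C`, with 0%
compound 2, `CC1(C)CCC(C)(C)c2cc(C(O)c3ccc4cc(C(=O)O)ccc4c3)c(O)cc21`, with 47%

Of the compounds shown here, two have been measured in an assay on isolated protein with retinoic acid receptor gamma (Homo sapiens) as the target; on this read-out higher numbers stand for larger maximal responses and lower numbers for smaller maximal responses. Compound 1 gives 0% and compound 2 gives 47%, so compound 2 stands highest of the two, with compound 1 far lower, beyond the scatter. The next compound, compound 3, `Cc1cc2c(cc1C(O)c1ccc3cc(C(=O)O)ccc3c1)C(C)(C)CCC2(C)C`, is not yet measured in this assay. It differs from compound 2 in one place: methyl in place of hydroxy on an aromatic carbon. Going by the values given here, no measured step covers this kind of change. Compound 3 is expected to fall below compound 2 by about a number 22 percentage points lower from compound 2 to compound 3 (beyond the scatter). The estimated result for compound 3 is 25%, within a range from 0% to 60%.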

Compound 3, largest response reached (reported as maximum), in percent of the reference or control that the assay uses: 82%
Beside the measured number, compound 3's estimate is 57 percentage points below it, outside the stated range (above it).
By their numbers in this assay, from the lowest: compound 1; then compound 2; then compound 3.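

At this place on an aromatic carbon, ortho to a large group, methyl in place of hydroxy gives a number 35 percentage points higher from compound 2 to compound 3 (beyond the scatter) in this assay and so a hydroxy is not required there for a high maximal response. Going by these compounds alone, the change removes the hydrogen-bond donor and acceptor counted for hydroxy, yet the response still rises, which the earlier compounds could not show. Nothing at hand accounts for this rise. As far as these compounds go, whether an ethyl group or a chlorine atom at this place would give a higher or lower response stays open, as does whether other groups here follow the same trend.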